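A benzyl amide in place of phenoxy

A few compounds are considered here, and "the series" means these few. Any claim that something is new, unique, unknown or untested is made for them only; others in the source may bear on it.

- compound 1 `c1ccc(-c2nc3ncccc3n2C2CCCC2)cc1`: 7000 nM
- compound 2 `c1ccc(Oc2ccc(-c3nc4cccnc4n3C3CCCC3)cc2)cc1`: > 10000 nM

In a functional assay on MDA-MB-231 cells (Homo sapiens) for cytotoxicity, read by MTT assay, with a stated time of 24 h (on this read-out higher numbers stand for weaker inhibition and lower numbers for stronger inhibition), compound 2 gives > 10000 nM, which is a limit of the assay and not a number. Compound 3 `O=C(NCc1ccccc1)c1ccc(-c2nc3cccnc3n2C2CCCC2)cc1` has benzylcarbamoyl in place of phenoxy on an aromatic carbon. Within the data shown here, no measured pair shows what such a change does. Among the measured compounds shown here, the only actual number is that of compound 1, at 7000 nM, so a small move toward stronger inhibition is expected at most. The expected change is an at least 1.6-fold lower number from compound 2 to compound 3 (0.22 log units; that floor lies within the scatter). The estimated value for compound 3 is 6000 nM, with an expected range of 2000 nM to 10000 nM.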

Compound 3, half-maximal inhibitory concentration: 620 nM
Compound 3: middle estimate off by 9.7-fold (0.99 log units), on the high side; the whole stated range lies above it.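

Putting benzylcarbamoyl in place of phenoxy on this aromatic carbon gives an at least 16-fold lower number from compound 2 to compound 3 (1.20 log units; beyond the scatter) in this assay. Among these compounds, the group at this position can therefore shift the read-out strongly, which the earlier compounds could not show. The value of compound 2 is a limit, so this step gives only a minimum size: the limit of > 10000 nM in this assay, at which 1 of the 3 values shown sits.

Which part of benzylcarbamoyl matters remains open: the amide hydrogen, the carbonyl or the terminal aromatic ring. A carboxylic acid or a methyl amide on the same carbon would help separate these parts.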